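This account rests on a few compounds, and the source may have more. Where it says the series, first, only, none or still open, it means among the compounds named here.

In an assay on CHO cells for displacement of a labelled ligand from adenosine receptor A2b (Homo sapiens), read by scintillation counting, with a stated time of 75 min, in the presence of a further agent that is not named here (on this read-out higher numbers stand for weaker inhibition and lower numbers for stronger inhibition), compound 3 `CCCn1c(=O)[nH]c2nc(-c3ccc(S(=O)(=O)N(C)C)cc3)[nH]c2c1=O` gives 18.6 nM, the highest of the three numbers. Compound 1 `CCCn1c(=O)[nH]c2nc(-c3ccc(S(=O)(=O)N4CCN(c5ccc(Cl)cc5F)CC4)cc3)[nH]c2c1=O` gives 1.91 nM and compound 2 `CCCn1c(=O)[nH]c2nc(-c3ccc(S(=O)(=O)N4CCN(c5ccc(Br)cc5)CC4)cc3)[nH]c2c1=O` gives 0.0835 nM; both carry a piperazine on the sulfonyl sulfur where compound 3 carries dimethylamino. Compound 4 `CCCn1c(=O)[nH]c2nc(-c3ccc(S(=O)(=O)N4CCN(C)CC4)cc3)[nH]c2c1=O` differs from compound 3 by 4-methylpiperazin-1-yl in place of dimethylamino on a sulfonyl sulfur. Among the measured compounds shown here, the only single step measured, a 23-fold lower number from compound 1 to compound 2 (1.36 log units; beyond the scatter), concerns the aryl group on the piperazine and does not touch the change from compound 3 to compound 4. The values of compound 1 and compound 2 beside compound 3 show that a piperazine on the sulfonyl sulfur goes with far lower numbers, yet both carry an aryl group that compound 4 lacks. A lower number beyond the scatter is therefore expected for compound 4, smaller than those gaps, estimated at 7 nM, within 2 nM to 25 nM, meaning a 2.7-fold lower number from compound 3 to compound 4 (0.42 log units; beyond the scatter).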

Compound 4, inhibition constant: 48.2 nM
Compound 4: the middle estimate sits 6.9-fold (0.84 log units) below what was measured; the measured number lies above the stated range.
By their numbers in this assay, from the lowest: compound 2; then compound 1; then compound 3; then compound 4.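

In this assay, 4-methylpiperazin-1-yl in place of dimethylamino on a sulfonyl sulfur gives a 2.6-fold higher number from compound 3 to compound 4 (0.41 log units; beyond the scatter) and so shows that the piperazine ring alone does not go with a lower number. The far lower numbers of the piperazines shown go with the aryl group on the amine nitrogen in the ring: methyl in its place gives a 580-fold higher number from compound 2 to compound 4 (2.76 log units; beyond the scatter) and a 25-fold higher number from compound 1 to compound 4 (1.40 log units; beyond the scatter) in these two pairs.

Open, as far as these compounds go, is where a benzyl group or an unsubstituted phenyl on that nitrogen would fall. Nothing available accounts for any of these steps.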